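Swapping the Amine Side Group on a Shared Core

This account rests on a few compounds, and the source may have more. Where it says the series, first, only, none or still open, it means among the compounds named here.

Measured compounds:
Compound 1 `Nc1ccc(Nc2c(C(=O)NCc3ccc(F)cc3)nc(Br)c3cccnc23)cc1`: in a functional assay on MCF7 cells (Homo sapiens) for cytotoxicity, read by MTT assay, with a stated time of 72 h (a higher number here means a weaker inhibitor, a lower number a stronger inhibitor), compound 1 gives 4000 nM.
Compound 2 `N[C@H]1CC[C@H](Nc2c(C(=O)NCc3ccc(Cl)cc3Cl)nc(Br)c3cccnc23)CC1`: in this assay compound 2 gives "not determined" (no result reported).

For the measured compounds named here, compound 1 therefore stands alone as the only compound with a number in this assay, so nothing here shows how a structural change moves that number. Compound 3 `CN(C)CCCNc1c(C(=O)NCc2ccc(F)cc2)nc(Br)c2cccnc12` differs from compound 1 in one place: 3-(dimethylamino)propyl in place of 4-aminophenyl on a nitrogen on an aromatic ring. Going by the values given here, with no step to compare, the expected change from compound 1 to compound 3 in this assay is no change at the digits printed from compound 1 to compound 3 (within the scatter), none beyond the scatter. Compound 3 is thus estimated at 4000 nM, within 1000 nM to 16000 nM.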

Compound 3, half-maximal inhibitory concentration: 7000 nM
Compound 3: the middle estimate sits 1.8-fold (0.24 log units) below what was measured; the range from low to high includes it.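

In this assay, for the compounds shown here, the swap gives a 1.8-fold higher number from compound 1 to compound 3 (0.24 log units; within the scatter) and so offers the first direct comparison at this position. On this nitrogen on an aromatic ring, an open chain with no ring can thus replace the ring-bearing 4-aminophenyl group without a change beyond the scatter. No available evidence bears on this result. One step cannot show how far this tolerance extends. Open questions include whether a longer chain, a morpholine at the chain end or a carboxylic acid would leave the value equally unchanged.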